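Swapping Nitro for Trifluoromethyl on a Benzyl Thioether

The source may report more compounds than this note shows. Statements on the series, on what has been measured and on what is new or still open speak of the compounds shown alone.

Compound 1, `C=CCSc1nc2cc(Cl)c(Cl)cc2n1C1O[C@H](CO)[C@@H](O)[C@H]1O`, gives 68000 nM in a functional assay on KB cells (Homo sapiens) for inhibition; a lower number here means a stronger inhibitor, a higher number a weaker inhibitor.
Compound 2, `N#CCSc1nc2cc(Cl)c(Cl)cc2n1C1O[C@H](CO)[C@@H](O)[C@H]1O`, reaches only a limit of the assay, > 100000 nM, in this assay.
Compound 3, `O=[N+]([O-])c1cccc(CSc2nc3cc(Cl)c(Cl)cc3n2C2O[C@H](CO)[C@@H](O)[C@H]2O)c1`, gives 25000 nM in this assay.

Compound 3 holds the lowest of the two numbers shown. The step of a 2.7-fold lower number from compound 1 to compound 3 (0.43 log units; beyond the scatter) is modest yet beyond the scatter. The step of an at least 4.0-fold lower number from compound 2 to compound 3 (0.60 log units; beyond the scatter) begins at a limit of the assay.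

Compound 4, `OC[C@H]1OC(n2c(SCc3cccc(C(F)(F)F)c3)nc3cc(Cl)c(Cl)cc32)[C@H](O)[C@@H]1O`, differs from compound 3 by trifluoromethyl in place of nitro on an aromatic carbon. Going by the values given here, every measured step exchanges the whole group on the saturated chain carbon bound to sulfur; none changes a substituent on the phenyl ring, so no measured step bears directly on this change. Therefore the expected step is no change at the digits printed from compound 3 to compound 4 (within the scatter), close to the scatter and with no firm direction. Compound 4 is estimated at 25000 nM, between 8000 nM and 80000 nM.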

Compound 4, half-maximal inhibitory concentration: 15000 nM
Compound 4: the middle estimate sits 1.7-fold (0.22 log units) above what was measured, within the range that was stated.
By their numbers in this assay, from the lowest: compounds 4 and 3 (each within the scatter of the next); then compound 1. At a limit, above all of these: compound 2.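

Going by these compounds alone, the first step that changes only a substituent on the phenyl ring reads a 1.7-fold lower number from compound 3 to compound 4 (0.22 log units; within the scatter) in this assay, so trifluoromethyl and nitro at this place cannot be told apart. The gain over vinyl is therefore not tied to nitro, as 3-(trifluoromethyl)phenyl also gives a 4.5-fold lower number from compound 1 to compound 4 (0.66 log units; beyond the scatter). The comparison with cyano, an at least 6.6-fold lower number from compound 2 to compound 4 (0.82 log units; beyond the scatter), starts from a limit of the assay and not a number: the limit of > 100000 nM in this assay, at which 1 of the 4 values shown sits.

Going by these compounds, it remains open whether an amine or a carboxylic acid at this ring carbon would keep the number in this range.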